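Swapping the amine side chain of compound 2

The source may hold more compounds than are shown below. What is called first, only, known or untested is meant among the compounds shown, and "the series" means these compounds.

Among the measured compounds shown here, in a functional assay on PC-3 cells (Homo sapiens) for cytotoxicity, read by MTT assay, with a stated time of 48 h (on this read-out higher numbers stand for weaker inhibition and lower numbers for stronger inhibition), compound 2 `CC(C)CNCC(=O)N1N=C(c2cc3ccccc3oc2=O)CC1c1ccccc1` gives 1920 nM, the lower of the two numbers known so far, while compound 1 `Cc1ccc(C(=O)N2N=C(c3cc4ccccc4oc3=O)CC2c2ccccc2)cc1` gives 13200 nM. For the measured compounds named here, the only measured step is a 6.9-fold lower number from compound 1 to compound 2 (0.84 log units; beyond the scatter). Compound 3 `O=C(CN1CCC(O)CC1)N1N=C(c2cc3ccccc3oc2=O)CC1c1ccccc1` differs from compound 2 by 4-hydroxypiperidin-1-yl in place of isobutylamino on a saturated chain carbon bound to a carbonyl carbon. That measured step exchanged 4-methylphenyl for (isobutylamino)methyl, whereas here one nitrogen-bearing group replaces another, so it bears only loosely on this change, and no shift beyond the scatter is expected in this assay. Compound 3 is therefore estimated at 2500 nM, within 800 nM to 8000 nM, a step of a 1.3-fold higher number from compound 2 to compound 3 (0.11 log units; within the scatter).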

Compound 3, half-maximal inhibitory concentration: "not active" (no number reported)
Compound 3: no number reported, so the estimate cannot be set against anything.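

Among the compounds shown here, compound 3 is reported only as "not active", without a number, so no step from compound 2 to compound 3 can be read. No available evidence explains this result. As far as these compounds go, how far 4-hydroxypiperidin-1-yl in place of isobutylamino moves the number remains open.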